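A few compounds are considered here, and "the series" means these few. Any claim that something is new, unique, unknown or untested is made for them only; others in the source may bear on it.

Measured compounds:
Compound 1, `O=c1[nH]cnc2c1c(-c1ccoc1)cn2[C@@H]1O[C@H](CO)[C@@H](O)[C@H]1O`, gives > 100000 nM; this is a limit of the assay.
Compound 2, `O=c1[nH]cnc2c1c(-c1cccs1)cn2[C@@H]1O[C@H](CO)[C@@H](O)[C@H]1O`, gives > 100000 nM; this too is a limit of the assay.
Compound 3, `Nc1nc(N)c2c(-c3cccs3)cn([C@@H]3O[C@H](CO)[C@@H](O)[C@H]3O)c2n1`, gives > 100000 nM; again a limit of the assay.

All three were tested in an ADME assay on BJ cells (Homo sapiens), read by MTT assay, with a stated time of 72 h; a lower number here means a stronger inhibitor, a higher number a weaker inhibitor. Compound 1 and compound 2 share a core and differ by furan-3-yl in place of thiophen-2-yl on an aromatic carbon; the step that the two limits leave unreadable from compound 2 to compound 1 cannot be sized because the limit of > 100000 nM in this assay, at which 3 of the 3 values shown sit, is where both values sit. The core of compound 3 differs from that of compound 2, but that difference is not broken down here.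

Compound 4, `Nc1nc(N)c2c(-c3ccoc3)cn([C@@H]3O[C@H](CO)[C@@H](O)[C@H]3O)c2n1`, is not yet measured. It differs from compound 3 by furan-3-yl in place of thiophen-2-yl on an aromatic carbon, the same change as from compound 2 to compound 1, at the same place. Since compound 3 sits at the limit of > 100000 nM in this assay, at which 3 of the 3 values shown sit, the step that the limit leaves unreadable from compound 3 to compound 4 is expected to be unreadable in the same way. Compound 4 is therefore estimated at 200000 nM in this assay.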

Compound 4, half-maximal inhibitory concentration: > 100000 nM
Compound 4 was reported as a limit; the forecaster's own chance of this, stated with the estimate: 90%; the middle value does not contradict the limit.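

The step from compound 3 to compound 4 cannot be read, since both values are limits of the assay: the limit of > 100000 nM in this assay, at which 4 of the 4 values shown sit.

The compounds shown leave open whether furan-3-yl and thiophen-2-yl differ at all in this assay.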